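This account rests on a few compounds, and the source may have more. Where it says the series, first, only, none or still open, it means among the compounds named here.

Of the compounds shown here, three have been measured in a physicochemical assay for lipophilicity; on this read-out higher numbers stand for higher lipophilicity and lower numbers for lower lipophilicity. Compound 1, with the structure `Cc1cc(Cl)cc(C)c1Nc1ccnc(Nc2ccc(C#N)cc2)n1`, gives 1.52. Compound 2, with the structure `Cc1cc(Br)cc(C)c1Nc1ccnc(Nc2ccc(C#N)cc2)n1`, gives 1.79. Compound 3, with the structure `Cc1cc(C#N)cc(C)c1Oc1nc(Nc2ccc(C#N)cc2)ncc1Br`, gives 1.82. Compound 2 and compound 1 differ in one place only: chloro in place of bromo on an aromatic carbon. That change goes with the step of a number 0.27 log units lower from compound 2 to compound 1 (within the scatter). Compound 3 has a different core from compound 2; the difference between the two cores is not broken down here, and the two values simply stand close to each other.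

Compound 4, with the structure `Cc1cc(C#N)cc(C)c1Oc1nc(Nc2ccc(C#N)cc2)ncc1Cl`, has not yet been measured in this assay. It differs from compound 3 in one place: chloro in place of bromo on an aromatic carbon. Among the measured compounds shown here, this is the same kind of change as the one from compound 2 to compound 1, but the surroundings differ. In compound 1 the chloro sits on a six-membered aromatic ring of carbon only, meta to two methyl groups and para to a large group; in compound 4 it sits on a six-membered aromatic ring with 2 nitrogen, ortho to a large group, two atoms from the ring nitrogen and para to a (4-cyanophenyl)amino group.

For the measured compounds named here, because the only comparable step measured is a number 0.27 log units lower from compound 2 to compound 1 (within the scatter), compound 4 is expected to show a step of about a number 0.27 log units lower from compound 3 to compound 4 (within the scatter). Compound 4 is therefore estimated at 1.55, most likely between 1.25 and 1.85.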

Compound 4, partition coefficient: 1.54
Compound 4: the middle estimate sits 0.01 log units above what was measured; the range from low to high includes it.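

In this assay, chloro in place of bromo on the core of compound 3 gives a number 0.28 log units lower from compound 3 to compound 4 (within the scatter), and this is almost the same size as the step on the other core, a number 0.27 log units lower from compound 2 to compound 1 (within the scatter), even though the halogen sits on a different ring in each pair. The change therefore carries across these two cores with much the same size, but each step lies within the usual scatter of repeated measurements, so neither pair on its own firmly separates chloro from bromo. Two pairs on two cores make no rule for any other core, and nothing shown here explains why the two steps match.

The compounds shown leave open whether fluoro or iodo on the same aromatic carbon would fit alongside chloro and bromo on both cores, which would test the comparison with more than one halogen swap. Among the compounds shown here, they also leave open how an amine or a carboxylic acid at that place would read in this assay, since every step so far exchanges one halogen for another.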